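Swapping Chloro for Bromo on a Shared Core

This account rests on a few compounds, and the source may have more. Where it says the series, first, only, none or still open, it means among the compounds named here.

Compound 1, `O=C1Nc2ccc(Cl)cc2/C1=C/c1cccc(OCc2cn(Cc3ccccc3)nn2)c1`, gives 24200 nM.
Compound 2, `O=C1Nc2cc(Cl)ccc2/C1=C\c1cccc(OCc2cn(Cc3ccccc3)nn2)c1`, gives 20100 nM.

Both numbers come from a functional assay on DU-145 cells (Homo sapiens) for inhibition, read by MTT assay, with a stated time of 48 h; on this read-out higher numbers stand for weaker inhibition and lower numbers for stronger inhibition. Compound 2 gives the lower of the two numbers, but the gap to compound 1 is within the usual scatter of repeated measurements, so the two compounds cannot be told apart and neither can be called the stronger inhibitor. Both sit at the weak end of what this assay reports.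

Compound 3, `O=C1Nc2cc(Br)ccc2/C1=C\c1cccc(OCc2cn(Cc3ccccc3)nn2)c1`, has not yet been measured. Set against compound 2 it carries bromo in place of chloro on an aromatic carbon. Among the measured compounds shown here, no pair of measured compounds in this small set differs by such a swap, so there is no measured step to lean on; the only anchor is the value of compound 2. Exchanging one halogen for another of the same kind is expected to move the number little, with no direction beyond the scatter. Compound 3 is therefore estimated at 18000 nM, within a range from 7000 nM to 45000 nM. The step of a 1.1-fold lower number from compound 2 to compound 3 (0.05 log units; within the scatter) that this estimate implies is expected to stay within the scatter.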

Compound 3, half-maximal inhibitory concentration: 5700 nM
Compound 3: middle estimate off by 3.2-fold (0.50 log units), on the high side; measured number outside the range, below it.
By their numbers in this assay, from the lowest: compound 3; then compounds 2 and 1 (each within the scatter of the next).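

Read in this assay, the exchange of chloro for bromo gives a 3.5-fold lower number from compound 2 to compound 3 (0.55 log units; beyond the scatter), so the number responds to which halogen sits at this place on the shared core, even though one single atom changes and the count of rings, hydrogen-bond donors and acceptors and charge stays the same. Compounds 1 and 2 could not show this, as they differ from each other in more than one place and their numbers lie within the scatter of each other. This is one pair of compounds, which gives the size of the step, but no measurement shown here offers a reason for it.

Going by these compounds, whether the number keeps changing with other groups at this place, such as fluoro, iodo, methoxy or an amine, remains open. Also open, on these data alone, is whether the same exchange would give a similar step on the core of compound 1, where the chloro sits elsewhere and the double bond has the other geometry.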